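The source may report more compounds than this note shows. Statements on the series, on what has been measured and on what is new or still open speak of the compounds shown alone.

Of the compounds shown here, three of this set have been tested in an ADME assay on MCF-10A cells (Homo sapiens) for cytotoxicity, read by sulforhodamine B assay, with a stated time of 72 h, tested at 30 uM; a lower number here means a weaker effect, a higher number a stronger effect of the compound at the concentration tested. Compound 1, `O=C(/C=C/c1cc(Br)ccc1O)c1ccc(Br)cc1`, gives 47.6%. Compound 2, `COC(=O)C1=C(N)Oc2c(OC)cc(Br)cc2C1CC(=O)c1ccc(Cl)cc1`, gives 47.8%. Compound 3, `COc1cc(Br)cc2c1OC(N)=C(C#N)C2CC(=O)c1ccccc1`, gives 45.9%. The number of compound 3 sits at the bottom of the three, but its gaps to compound 1 and to compound 2 both lie within the scatter of repeated measurements, so the three readings cannot be told apart and none of the compounds can be called more or less active than the others.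

Compound 4, `COc1cc(Br)cc2c1OC(N)=C(C#N)C2CC(=O)c1ccc(Cl)cc1`, has not yet been measured. It differs from compound 3 in one place: chloro in place of hydrogen on an aromatic carbon. Compound 2 already carries a 4-chlorophenyl group, and its reading of 47.8% stands level with the phenyl compound 3, which gives no hint that the chloro group changes the reading. The step is therefore expected to be none beyond the scatter, with a number 1.1 percentage points higher from compound 3 to compound 4 (within the scatter) as the estimated size. Compound 4 is expected to give 47%, within a range from 37% to 57%.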

Compound 4, a percentage reported as activity, at one concentration (the size of the read-out at that concentration, not a potency): 41.6%
For compound 4 the middle estimate is 5.4 percentage points above the measured one; low and high end bracket the measured number.
By their numbers in this assay, from the lowest: compounds 4, 3, 1 and 2 (each within the scatter of the next).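

In this assay, chloro in place of hydrogen on an aromatic carbon, para to a large group, comes with a number 4.3 percentage points lower from compound 3 to compound 4 (within the scatter), so this first reading of the change from phenyl to 4-chlorophenyl cannot be told from the scatter. With the 4-chlorophenyl group held in place, cyano in place of methoxycarbonyl on a double-bonded ring carbon comes with a number 6.2 percentage points lower from compound 2 to compound 4 (within the scatter), so this position also shows no change that stands clear of the scatter. No measurement is available that bears on either step.

Going by these compounds, whether an amine or a carboxylic acid on the same aromatic carbon would move the reading beyond the scatter stays open. The compounds shown also hold no phenyl counterpart of compound 2, so the chloro step remains unread with methoxycarbonyl on the core.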